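A few compounds are considered here, and "the series" means these few. Any claim that something is new, unique, unknown or untested is made for them only; others in the source may bear on it.

Compound 1 `CN(CC1=CC[C@H]2C[C@@H]1C2(C)C)Cc1ccc(-c2ccccc2)cc1` gives 3160 nM in an assay on HEK293 cells for displacement of a labelled ligand from C-X-C chemokine receptor type 3 (Homo sapiens); a lower number here means a stronger inhibitor, a higher number a weaker inhibitor.
Compound 2 `CN(CC1=CC[C@H]2C[C@@H]1C2(C)C)Cc1ccc(-c2cccc(F)c2)cc1` gives 2510 nM in this assay.
For compound 3 `CN(CC1=CC[C@H]2C[C@@H]1C2(C)C)Cc1ccc(-c2cccc(C(F)(F)F)c2)cc1` this assay reports only a limit, > 316 nM.

Compound 3 therefore stands at the limit of this assay, (the limit of > 316 nM in this assay, at which 1 of the 3 values shown sits), and no number is known for it. The change that leads from compound 3 to compound 4 `COC(=O)c1cccc(-c2ccc(CN(C)CC3=CC[C@H]4C[C@@H]3C4(C)C)cc2)c1` is methoxycarbonyl in place of trifluoromethyl on an aromatic carbon. Of the measured steps, those that end at compound 3 bear most directly on this change: a step that the limit leaves unreadable from compound 1 to compound 3 and a step that the limit leaves unreadable from compound 2 to compound 3. Neither can be read in size. Among the compounds with values here, the only readable step, a 1.3-fold lower number from compound 1 to compound 2 (0.10 log units; within the scatter), lies within the scatter. Within the data shown here, the measured compounds thus give no readable size for the step in this assay, and the two numbers known, from compound 1 and compound 2, both sit in one region. Compound 4 is expected to fall near those two numbers, with an estimate of 2500 nM, between 700 nM and 9000 nM. The step this means from the limit of compound 3, a step that the limit leaves unreadable from compound 3 to compound 4, is an expectation only.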

Compound 4, inhibition constant: > 316 nM
Compound 4: only a limit was reported; the forecaster's own chance of this, stated with the estimate: 30%; the middle value is on the limit's open side.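

Compound 4, like compound 3, has only a limit in this assay, so no step to compound 4 from compound 1, compound 2 or compound 3 can be read: the limit of > 316 nM in this assay, at which 2 of the 4 values shown sit.

The compounds shown leave open where compound 3 and compound 4 stand relative to each other and to compound 1 and compound 2.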